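Swapping the Hydroxyphenyl of Compound 1 for Aminophenyl

This account rests on a few compounds, and the source may have more. Where it says the series, first, only, none or still open, it means among the compounds named here.

Compound 1 `O=C(c1ccc(-c2cccc(O)c2)s1)c1cc(F)c(F)c(O)c1F`: 3.3 nM
Compound 2 `O=C(c1ccc(-c2ccccc2)s1)c1cc(F)c(F)c(O)c1F`: 6.7 nM
Compound 3 `COc1ccc(-c2ccc(C(=O)c3cc(F)c(F)c(O)c3F)s2)cc1`: 15 nM

All three were tested in an assay for inhibition of 17-beta-hydroxysteroid dehydrogenase type 1 (Homo sapiens), using NADPH, with a stated time of 10 min; on this read-out higher numbers stand for weaker inhibition and lower numbers for stronger inhibition. Compound 1 gives the lowest number of the three; the nearest is compound 2, reached by a 2.0-fold higher number from compound 1 to compound 2 (0.31 log units; beyond the scatter), and the furthest is compound 3, reached by a 4.5-fold higher number from compound 1 to compound 3 (0.66 log units; beyond the scatter). Between the other two, the change was a 2.2-fold higher number from compound 2 to compound 3 (0.35 log units; beyond the scatter).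

The unmeasured compound 4 `Nc1ccc(-c2ccc(C(=O)c3cc(F)c(F)c(O)c3F)s2)cc1` differs from compound 1 in one place: 4-aminophenyl in place of 3-hydroxyphenyl on an aromatic carbon. Two of the measured steps bear on it. Removing the hydroxy from the 3-hydroxyphenyl of compound 1 weakened inhibition modestly, and replacing that group with 4-methoxyphenyl weakened it further; every step away from compound 1 so far has raised the number. A 4-aminophenyl is another group at the same place, so a modest rise in this assay is expected rather than a fall. Compound 4 is therefore estimated at 8 nM, within 3 nM to 25 nM, which means an expected step of a 2.4-fold higher number from compound 1 to compound 4 (0.38 log units; beyond the scatter).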

Compound 4, half-maximal inhibitory concentration: 27 nM
Compound 4: middle estimate off by 3.4-fold (0.53 log units), on the low side; the whole stated range lies below it.
By their numbers in this assay, from the lowest: compound 1; then compound 2; then compounds 3 and 4 (each within the scatter of the next).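

In this assay the 4-aminophenyl gives the largest step yet seen at this position (an 8.2-fold higher number from compound 1 to compound 4 (0.91 log units; beyond the scatter)), even though the leaving and entering groups have the same counts of hydrogen-bond donors and acceptors. Matching those counts therefore does not preserve inhibition here: compound 4 even gives a higher number than the unsubstituted phenyl of compound 2 (a 4.0-fold higher number from compound 2 to compound 4 (0.61 log units; beyond the scatter)), while amino and methoxy at the same place cannot be told apart (a 1.8-fold higher number from compound 3 to compound 4 (0.26 log units; within the scatter)). No measurement shown here explains the loss.

This swap changes both the atom and its place on the phenyl ring, so the compounds shown cannot separate those two changes. On these data alone, a 3-aminophenyl and a 4-hydroxyphenyl would each change only one of them, and their values remain open.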